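Swapping Ethynyl for Phenyl: An Expected Inhibition Value

The source may report more compounds than this note shows. Statements on the series, on what has been measured and on what is new or still open speak of the compounds shown alone.

Compound 1 `OC(Cc1ccccc1)c1cccc2[nH]ncc12` and compound 2 `C#Cc1cc(C(O)Cc2ccccc2)c2cn[nH]c2c1` share a core and differ at one aromatic carbon. In an assay for inhibition of Indoleamine 2,3-dioxygenase 1 variant C129Y (Homo sapiens), read by spectrophotometry, with a stated time of 30 min, tested at 10 uM (a lower number here means less inhibition, a higher number more inhibition at the concentration tested (going by the name of the read-out)), compound 1 gives 14%, and compound 2 gives 12%. For the measured compounds named here, the single measured step, a number 2 percentage points lower from compound 1 to compound 2 (within the scatter), puts ethynyl in place of hydrogen on an aromatic carbon. Compound 2 stands lowest of the two numbers, but its gap to compound 1 is within the scatter, so no order between the two can be claimed.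

Compound 3 `OC(Cc1ccccc1)c1cc(-c2ccccc2)cc2[nH]ncc12` is not yet measured. It differs from compound 2 by phenyl in place of ethynyl on an aromatic carbon. Going by the values given here, the only measured step touching this aromatic carbon, hydrogen to ethynyl, changed the number little, so it gives weak guidance, and no step with phenyl entering exists among the measured compounds. Both measured values are low. Compound 3 is therefore expected to stay near those values, with a number 3 percentage points higher from compound 2 to compound 3 (within the scatter) expected to fall within the scatter. The estimate for compound 3 in this assay is 15%, ranging from 0% to 35%.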

Compound 3, a percentage reported as inhibition, at one concentration (the size of the read-out at that concentration, not a potency): 14%
For compound 3 the middle estimate is 1 percentage points above the measured one; low and high end bracket the measured number.
By their numbers in this assay, from the lowest: compounds 2, 1 and 3 (each within the scatter of the next).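

In this assay, replacing ethynyl with the larger phenyl group, which has 6 heavy atoms against 2 and adds a six-membered aromatic ring, gives a number 2 percentage points higher from compound 2 to compound 3 (within the scatter). Compared with the unsubstituted compound, phenyl in place of hydrogen gives no change at the digits printed from compound 1 to compound 3 (within the scatter), so this aromatic carbon has now carried hydrogen, ethynyl and phenyl, and no two of the three compounds lie beyond the scatter of each other. The flat picture therefore extends from a small, ringless group to a whole aromatic ring at this position, but no supporting measurement offers a reason for it.

Ethynyl and phenyl both count 0 hydrogen-bond donors and 0 hydrogen-bond acceptors, so it remains open whether an amine or a carboxylic acid on this same carbon would lift the number beyond the scatter. These readings also come from a single concentration and all sit low, which leaves open how the three compounds would compare at other concentrations and whether a change elsewhere on the shared core would have a larger effect.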